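Swapping a fluoroindanyl for a dimethylaminophenyl on a sulfonamide

A few compounds are considered here, and "the series" means these few. Any claim that something is new, unique, unknown or untested is made for them only; others in the source may bear on it.

Measured so far:
- compound 1, `CC(C)CN(C1CCc2ccc(F)cc21)S(=O)(=O)c1ccc2c(c1)C(=O)CC(C1CCOCC1)O2`: 4.03
- compound 2, `CCc1ccc(N(CC(C)C)S(=O)(=O)c2ccc3c(c2)C(=O)CC(C2CCN(C(=O)C4CCCC4)CC2)O3)cc1`: 5.13

Both compounds were characterised in a physicochemical assay for lipophilicity, at pH 7.4; a higher number here means a more lipophilic compound, a lower number a more polar compound. Compound 1 gives 4.03 in this assay, the lower of the two numbers; compound 2 gives 5.13, a number beyond the usual scatter above compound 1. For the measured compounds named here, no pair of measured compounds differs in a single place, so there is no measured step to lean on.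

Compound 3, `CC(C)CN(c1ccc(N(C)C)cc1)S(=O)(=O)c1ccc2c(c1)C(=O)CC(C1CCOCC1)O2`, has not yet been measured. It differs from compound 1 in one place: 4-(dimethylamino)phenyl in place of 6-fluoro-2,3-dihydro-1H-inden-1-yl on a sulfonamide nitrogen.

Going by the values given here, with no comparable step available, the expectation for compound 3 rests on the change itself and on where compound 1 stands. Compound 3 is expected to be less lipophilic than compound 1, with an estimated step of a number 0.73 log units lower from compound 1 to compound 3 (beyond the scatter) in this assay, clearly beyond the scatter. The estimated value for compound 3 in this assay is 3.3, with a likely range from 2.7 to 3.9.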

Compound 3, distribution coefficient: 3.6
For compound 3 the middle estimate is 0.30 log units below the measured one, within the range that was stated.
By their numbers in this assay, from the lowest: compound 3; then compound 1; then compound 2.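

In this assay, for the compounds shown here, 4-(dimethylamino)phenyl in place of 6-fluoro-2,3-dihydro-1H-inden-1-yl on a sulfonamide nitrogen gives a number 0.43 log units lower from compound 1 to compound 3 (beyond the scatter), and this is the first step that can be read at a single place, since compound 1 and compound 2 differ in more than one. The number therefore responds to a change on this nitrogen alone, with the rest of compound 1 left as it stands. The change removes the five-membered ring and the fluorine and brings in a dimethylamino group with one hydrogen-bond acceptor, but nothing available here shows which of these changes accounts for the step.

A plain phenyl or a 4-fluorophenyl on the same nitrogen would help to separate these parts of the change. From the compounds shown here alone, how a carboxylic acid or a longer alkyl chain on that phenyl ring would compare with compound 3 also stays open.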